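The source may hold more compounds than are shown below. What is called first, only, known or untested is meant among the compounds shown, and "the series" means these compounds.

Of the compounds shown here, three have so far been tested in a functional assay on A549 cells (Homo sapiens) for cytotoxicity, read by sulforhodamine B assay, with a stated time of 48 h; on this read-out higher numbers stand for weaker inhibition of growth and lower numbers for stronger inhibition of growth. Compound 1 `ClCc1ccccc1Cn1cnc2c(Cl)nc(Cl)nc21` gives 4670 nM. Compound 2 `ClCc1ccccc1Cn1cnc2c(Cl)ncnc21`, which carries one chloro group fewer on the shared core, gives 25700 nM. Compound 3 `ClCc1cccc(Cn2cnc3ncnc(Cl)c32)c1` gives 39800 nM; the values of compound 2 and compound 3 lie within the usual scatter of each other, and the difference between the cores of compound 2 and compound 3 is not broken down here.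

Within the data shown here, the one change that has been measured on its own is the step from compound 2 to compound 1: chloro in place of hydrogen on an aromatic carbon. In this assay it made a 5.5-fold lower number from compound 2 to compound 1 (0.74 log units; beyond the scatter).

Compound 4 `ClCc1cccc(Cn2cnc3nc(Cl)nc(Cl)c32)c1` has not yet been measured. Its relation to compound 3 is chloro in place of hydrogen on an aromatic carbon, the same change at a place described in the same words. Among the measured compounds shown here, a step of similar size is therefore expected from compound 3 to compound 4, a 5.0-fold lower number from compound 3 to compound 4 (0.70 log units; beyond the scatter), because a 5.5-fold lower number from compound 2 to compound 1 (0.74 log units; beyond the scatter) is the only guide available. Compound 4 is accordingly estimated at 8000 nM, with a likely range from 3500 nM to 20000 nM.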

Compound 4, concentration for total growth inhibition: 25700 nM
The estimate for compound 4 lay 3.2-fold (0.51 log units) below the measured number; the whole stated range lies below it.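

Putting a chloro group in place of hydrogen on the aromatic carbon between two ring nitrogen atoms does not carry over from one core to the other at the same size: in this assay it gives a 1.5-fold lower number from compound 3 to compound 4 (0.19 log units; within the scatter), a step that cannot be told apart from the usual scatter. Set beside the earlier step, the result on the first core is not repeated on the second: the same change on two cores in this assay, a 5.5-fold lower number (0.74 log units; beyond the scatter) from compound 2 to compound 1 and a 1.5-fold lower number (0.19 log units; within the scatter) from compound 3 to compound 4, 3.6-fold (0.55 log units) apart, beyond the scatter of two such steps
Among these compounds, this shows that the size of the step depends on the core in this small series, but it does not show which feature of the cores is responsible, since the two cores differ in a way not broken down here and only two pairs are available.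

As far as these compounds go, it remains open whether an amine or a methoxy group on that same carbon would also behave differently on the two cores. Also open, from the compounds shown here alone, is what part the chloromethyl group plays, which a plain methyl or a hydroxymethyl group in its place would help to test.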